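Thiophene for Fluorophenyl on a Spiro Oxindole Scaffold

The source may hold more compounds than are shown below. What is called first, only, known or untested is meant among the compounds shown, and "the series" means these compounds.

Measured so far:
Compound 1, `CN1C[C@@H](c2ccccc2)[C@@]2(Cc3ccccc3C2=O)[C@@]12C(=O)Nc1ccccc12`: 40%
Compound 2, `CN1C(=O)[C@@]2(c3ccccc31)N(C)C[C@@H](c1ccc(F)cc1)[C@@]21Cc2ccccc2C1=O`: 24.6%

Two compounds have been examined in a functional assay on the whole organism (strain Wister albino) for inhibition, with Rattus norvegicus as the target, read by paw edema, with stated times of 1 h and 2 h, at a dose of 50 mg/kg by the intraperitoneal route; a higher number here means more inhibition at the dose given (going by the name of the read-out), a lower number less inhibition. Compound 1 gives 40% in this assay, and compound 2 gives 24.6%. Compound 2 therefore stands lowest of the two numbers; its nearest neighbour is compound 1, whose value lies higher by a gap beyond the usual scatter. Among the compounds with values here, the two structures differ in more than one place, so no single step between them can be read.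

Compound 3 `CN1C(=O)[C@@]2(c3ccccc31)N(C)C[C@@H](c1cccs1)[C@@]21Cc2ccccc2C1=O` differs from compound 2 by the change (thiophen-2-yl in place of 4-fluorophenyl on a saturated ring carbon). Nothing measured here bears directly on that exchange, so no direction can be drawn from the data. The expected step of a number 2.4 percentage points higher from compound 2 to compound 3 (within the scatter) is small, not beyond the scatter in this assay. Compound 3 is estimated at 27%, with a range from 12% to 44%.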

Compound 3, a percentage reported as inhibition, in the whole organism at one dose (the size of the read-out at that dose, not a potency): 10.8%
Beside the measured number, compound 3's estimate is 16.2 percentage points above it; the whole stated range lies above it.
By their numbers in this assay, from the lowest: compound 3; then compound 2; then compound 1.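

In this assay, within the data shown here, putting thiophen-2-yl in place of 4-fluorophenyl on the saturated ring carbon gives a number 13.8 percentage points lower from compound 2 to compound 3 (beyond the scatter), the only step in this set that can be read at a single place. It shows that this position is not indifferent to the aromatic ring it carries: with the rest of the structure unchanged, this exchange alone lowers the inhibition seen at the dose given. No further measurement at hand bears on why the number falls.

This single step does not separate the change in ring size from the entry of sulfur or the loss of fluorine. Going by these compounds, how a pyridin-3-yl ring or a carboxylic acid on the same carbon would read in this assay also remains open.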